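Ortho-substituent swap on the arylidene indanone core

The compounds below may be only part of what the source reports. "The series", "measured", "known", "first", "only" and "open" are said of these compounds alone.

Measured compounds: compound 1 `O=C1/C(=C/c2ccccc2Cl)Cc2ccccc21` with 152000 nM; compound 2 `O=C1/C(=C/c2ccccc2F)Cc2ccccc21` with 150000 nM; compound 3 `O=C1/C(=C/c2ccccc2[N+](=O)[O-])Cc2ccccc21` with 7610 nM, all in a functional assay on L1210 cells (Mus musculus) for inhibition; a higher number here means a weaker inhibitor, a lower number a stronger inhibitor.

Compound 3 stands lowest of the three numbers in this assay, the other two sitting a long way above it. Compound 4 `Cc1ccccc1/C=C1\Cc2ccccc2C1=O` differs from it by methyl in place of nitro on an aromatic carbon. Within the data shown here, no measured step involves a methyl, but two bear on the nitro group: a 20-fold lower number from compound 1 to compound 3 (1.30 log units; beyond the scatter) and a 20-fold lower number from compound 2 to compound 3 (1.29 log units; beyond the scatter). Both show that removing nitro in favour of a small substituent costs a large amount, so the step of a 13-fold higher number from compound 3 to compound 4 (1.12 log units; beyond the scatter) is expected to move compound 4 back toward the halogen compounds. Compound 4 is therefore estimated at 100000 nM, in the range 30000 nM to 400000 nM.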

Compound 4, half-maximal inhibitory concentration: 208000 nM
For compound 4 the middle estimate is 2.1-fold (0.32 log units) below the measured one; measured number inside the range.
By their numbers in this assay, from the lowest: compound 3; then compounds 2, 1 and 4 (each within the scatter of the next).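

Methyl in place of nitro gives a 27-fold higher number from compound 3 to compound 4 (1.44 log units; beyond the scatter) in this assay while the steps of a 1.4-fold higher number from compound 2 to compound 4 (0.14 log units; within the scatter) and a 1.4-fold higher number from compound 1 to compound 4 (0.14 log units; within the scatter) stay within the scatter. At this position, then, methyl groups with chloro and fluoro, and among the four groups only nitro sets its compound apart. No measurement shown accounts for this separation.

From the compounds shown here alone, it remains open whether the low number belongs to nitro alone or would be shared by other groups at this position, such as a nitrile, an amine or a carboxylic acid.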